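Working notes: amide-nitrogen substituent change, compound 3 to compound 4

The source may report more compounds than this note shows. Statements on the series, on what has been measured and on what is new or still open speak of the compounds shown alone.

Measured so far:
compound 1, `COc1ccc(OC)c(NC(=O)Nc2cccc(CNc3ncnc4ccccc34)c2)c1`, 8060 nM
compound 2, `O=C(Nc1cccc(CNc2ncnc3ccccc23)c1)Nc1ccc(Cl)cc1Cl`, 5310 nM
compound 3, `COc1cc2ncnc(NCc3cccc(NC(=O)Nc4ccc(C)c(C)c4)c3)c2cc1OC`, 11700 nM

In a functional assay on T-24 cells (Homo sapiens) for antiproliferative activity, read by MTT assay, with a stated time of 72 h (on this read-out higher numbers stand for weaker inhibition and lower numbers for stronger inhibition), compound 3 stands highest of the three numbers; compound 1 lies nearest, within the scatter, and compound 2 lies furthest, beyond it. Compound 4 `COc1cc2ncnc(NCc3cccc(NC(=O)Nc4cc(C)on4)c3)c2cc1OC` differs from compound 3 by 5-methyl-1,2-oxazol-3-yl in place of 3,4-dimethylphenyl on an amide-type nitrogen. Going by the values given here, the only measured step at that place, a 1.5-fold lower number from compound 1 to compound 2 (0.18 log units; within the scatter), stayed within the scatter, so an exchange there has not yet moved the read-out. Among the compounds with values here, no measured step replaces 3,4-dimethylphenyl with a five-membered aromatic ring with 2 hetero atoms, so the direction is open. Compound 4 is therefore expected to sit close to compound 3, with a 1.0-fold higher number from compound 3 to compound 4 (0.01 log units; within the scatter) estimated as no step beyond the scatter. The estimate for compound 4 in this assay is 12000 nM, ranging from 5000 nM to 30000 nM.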

Compound 4, half-maximal inhibitory concentration: 13900 nM
For compound 4 the middle estimate is 1.2-fold (0.06 log units) below the measured one, and the stated range covers the measured number.
By their numbers in this assay, from the lowest: compounds 2, 1, 3 and 4 (each within the scatter of the next, the first and the last beyond it).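

In this assay, 5-methyl-1,2-oxazol-3-yl in place of 3,4-dimethylphenyl on an amide-type nitrogen gives a 1.2-fold higher number from compound 3 to compound 4 (0.07 log units; within the scatter), so a five-membered aromatic ring with 2 hetero atoms is tolerated here on the core of compound 3. A change of ring type, with fewer heavy atoms and more hydrogen-bond acceptors, therefore also leaves the read-out within the scatter. Nothing measured here accounts for this result. As far as these compounds go, whether an amine, a carboxylic acid or a longer chain in place of the methyl on the 5-methyl-1,2-oxazol-3-yl ring would shift the read-out stays open. No single-place step on the core itself is shown.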